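This account rests on a few compounds, and the source may have more. Where it says the series, first, only, none or still open, it means among the compounds named here.

Measured so far:
- compound 1, `CN1CCN(c2ccc(NC(=N)c3cc4c(-c5ccccc5)n[nH]c4c(NC4CCCCC4)n3)cc2)CC1`: 4630 nM
- compound 2, `COc1ccc(Cn2nc(-c3ccccc3)c3cc(C(=N)Nc4ccccc4)nc(NC4CCCCC4)c32)cc1`: 1100 nM

In a functional assay on PC-3 cells (Homo sapiens) for cytotoxicity, read by MTT assay, with a stated time of 72 h (a lower number here means a stronger inhibitor, a higher number a weaker inhibitor), compound 2 gives the lower of the two numbers, and compound 1 gives a number that is higher by a margin beyond the usual scatter. Compound 2 is thus the stronger of the two on this assay. Compound 3, `COc1ccc(Cn2nc(-c3ccccc3)c3cc(C(=N)Nc4ccc(N5CCN(C)CC5)cc4)nc(NC4CCCCC4)c32)cc1`, differs from compound 2 in one place: 4-methylpiperazin-1-yl in place of hydrogen on an aromatic carbon. Compound 1 already carries this same group on the same ring, but it also differs from compound 2 elsewhere, so the two values show only that the pattern with this group and the other change together gave a weaker inhibitor. No single-step comparison exists for this change. The expectation is a step for compound 3 that is small, toward a weaker inhibitor or none beyond the scatter, in this assay. For compound 3 the estimate is 2000 nM with a range from 700 nM to 6000 nM, which corresponds to an expected 1.8-fold higher number from compound 2 to compound 3 (0.26 log units; within the scatter).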

Compound 3, half-maximal inhibitory concentration: 3540 nM
Beside the measured number, compound 3's estimate is 1.8-fold (0.25 log units) below it, and the stated range covers the measured number.
By their numbers in this assay, from the lowest: compound 2; then compounds 3 and 1 (each within the scatter of the next).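

Among these compounds, with the 4-methoxybenzyl group in place, putting 4-methylpiperazin-1-yl in place of hydrogen on the aromatic carbon gives, in this assay, a 3.2-fold higher number from compound 2 to compound 3 (0.51 log units; beyond the scatter), the first reading of this change on its own, and it points to a modestly weaker inhibitor. The second step concerns the aromatic nitrogen: with 4-methylpiperazin-1-yl present, 4-methoxybenzyl in place of hydrogen there gives a 1.3-fold lower number from compound 1 to compound 3 (0.12 log units; within the scatter), so that swap makes no difference that stands out from the scatter. Nothing available here explains either step.

Still open, as far as these compounds go, is whether 4-methoxybenzyl on that nitrogen would matter in a compound lacking 4-methylpiperazin-1-yl. From the compounds shown here alone, it is also open how other groups on the same aromatic carbon, such as morpholine, a dimethylamino group or a carboxylic acid, would compare with hydrogen.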